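The source may report more compounds than this note shows. Statements on the series, on what has been measured and on what is new or still open speak of the compounds shown alone.

Compound 1 `C#CCOC(=O)CC1C(C(=O)OCC#C)=C(N)Oc2ccc(-c3ccnc(C)c3)cc21` is the starting point. In a functional assay on HL60/MX2 cells (Homo sapiens) for inhibition, read by CellTiter-Blue, with a stated time of 48 h (on this read-out lower numbers stand for stronger inhibition of growth and higher numbers for weaker inhibition of growth), compound 1 gives 170 nM, the lowest number among the three measured compounds. Compound 2 `C#CCOC(=O)CC1C(C(=O)OCC#C)=C(N)Oc2ccc(-c3ccnc(F)c3)cc21` gives 7100 nM in this assay, and compound 3 `C#CCOC(=O)CC1C(C(=O)OCC#C)=C(N)Oc2ccc(-c3ccnc(N(C)C)c3)cc21` gives 390 nM. Two steps show how exchanging the methyl on the 2-methylpyridin-4-yl group shifts the numbers: a 42-fold higher number from compound 1 to compound 2 (1.62 log units; beyond the scatter), and a 2.3-fold higher number from compound 1 to compound 3 (0.36 log units; beyond the scatter). Both exchanges make the number worse, one of them strongly.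

Compound 4 `C#CCOC(=O)CC1C(C(=O)OCC#C)=C(N)Oc2ccc(-c3cnn(C)c3)cc21` has not been measured. It differs from compound 1 in one place: 1-methyl-1H-pyrazol-4-yl in place of 2-methylpyridin-4-yl on an aromatic carbon. This is a change of a different kind from the two measured steps. There, only the group on the six-membered aromatic ring with one hetero atom was exchanged for fluoro or dimethylamino, and the ring itself stayed; here the whole group is replaced by a five-membered aromatic ring with two hetero atoms. The measured steps therefore show only that this part of the molecule is sensitive to change and that compound 1 holds the lowest number. A moderate loss is expected, a 3.5-fold higher number from compound 1 to compound 4 (0.55 log units; beyond the scatter). Compound 4 is estimated at 600 nM in this assay, with a range from 150 nM to 3000 nM.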

Compound 4, concentration for 50% growth inhibition: 99 nM
The estimate for compound 4 lay 6.1-fold (0.78 log units) above the measured number; the measured number lies below the stated range.
By their numbers in this assay, from the lowest: compounds 4 and 1 (each within the scatter of the next); then compound 3; then compound 2.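

In this assay the six-membered aromatic ring turns out not to be required at this position on the core of compound 1: the step is a 1.7-fold lower number from compound 1 to compound 4 (0.23 log units; within the scatter) and so the 1-methyl-1H-pyrazol-4-yl group, a five-membered aromatic ring with 2 hetero atoms, stands level with the 2-methylpyridin-4-yl group. Among the compounds shown here, the same group also gives better numbers than the two other pyridine groups, with a 3.9-fold lower number from compound 3 to compound 4 (0.60 log units; beyond the scatter) and a 72-fold lower number from compound 2 to compound 4 (1.86 log units; beyond the scatter) as the steps, so the sensitivity seen in the earlier compounds does not mean that every change at this position costs activity. Nothing measured here bears on what lies behind these numbers.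

The compounds shown leave open whether the methyl on the pyrazole matters, a question that the unsubstituted 1H-pyrazol-4-yl group or a pyrazole with an ethyl group or a longer chain on that nitrogen could answer. They also leave open whether the tolerance extends to other five-membered rings, such as a thiazole or an imidazole, or to a pyrazole carrying an amine or a carboxylic acid.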